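The source may hold more compounds than are shown below. What is called first, only, known or untested is meant among the compounds shown, and "the series" means these compounds.

Working notes on the series: compound 1 `COC(=O)c1c[nH]c2ccc(Cl)cc2c1=O` and compound 2 `COC(=O)c1c[nH]c2ccc(Oc3ccc(F)cc3)cc2c1=O` have both been measured in an ADME assay on J774 cells (Mus musculus) for cytotoxicity; on this read-out lower numbers stand for an effect already at smaller amounts and higher numbers for an effect only at larger amounts of compound. Compound 1 gives > 20000 nM, which is a limit of the assay. Compound 2 gives > 20000 nM, also a limit of the assay, and so stands at the limit of > 20000 nM in this assay, at which 2 of the 2 values shown sit. Compound 3 `COC(=O)c1c[nH]c2ccc(Oc3ccccc3)cc2c1=O` differs from compound 2 by hydrogen in place of fluoro on an aromatic carbon, para to a large group. Within the data shown here, no measured step in this assay gives a size for this change, so no shift beyond the scatter is expected in either direction. The expected move is a number no higher from compound 2 to compound 3 (the limit leaves the size open). Compound 3 is estimated at 20000 nM, with an expected range of 10000 nM to 40000 nM.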

Compound 3, half-maximal effective concentration: > 20000 nM
Compound 3 ended at the assay's limit (the forecaster's own chance of this, stated with the estimate: 85%); the middle value sits exactly at the limit.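

Compound 3 gives > 20000 nM, a limit of the assay. Among these compounds, no step from compound 1 or compound 2 to compound 3 can be read. The compounds shown leave open at what concentration any of them would register an effect in this assay: the limit of > 20000 nM in this assay, at which 3 of the 3 values shown sit.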